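Methyl on the pyrazole in the microsomal clearance series

The compounds below may be only part of what the source reports. "The series", "measured", "known", "first", "only" and "open" are said of these compounds alone.

Three compounds of the series have numbers in an ADME assay on microsomes from liver (Homo sapiens) for metabolic stability, read by LC-MS, using NADPH, with stated times of 5 min and 30 min, tested at 1 uM; on this read-out higher numbers stand for fast clearance and lower numbers for slow clearance. Compound 1 `Cn1cc(-c2cnc(NCc3c(F)ccc4c3CCO4)c3cn[nH]c(=O)c23)cn1` gives 21 mL.min-1.g-1 in this assay, the second highest of the three. Compound 3 `CN(C)Cc1ccc2c(c1)CN(c1cnc(NCc3c(F)ccc4c3CCO4)c3cn[nH]c(=O)c13)C2=O` gives 32 mL.min-1.g-1, within the scatter of compound 1. Compound 2 `Cc1ncccc1-c1cnc(NCc2c(F)ccc3c2CCO3)c2n[nH]c(=O)n12` gives 8 mL.min-1.g-1, a lower number beyond the scatter. Compound 4 `Cc1nn(C)cc1-c1cnc(NCc2c(F)ccc3c2CCO3)c2cn[nH]c(=O)c12` has not been measured. Compared with compound 1 the change is methyl in place of hydrogen on an aromatic carbon. Within the data shown here, no measured pair shows this same change, so nothing here tells its effect; the expectation rests only on the small size of the change as counted. The step of a 1.0-fold higher number from compound 1 to compound 4 (0.02 log units; within the scatter) is expected to stay within the scatter, in no particular direction. Compound 4 is estimated at 22 mL.min-1.g-1, with a range from 10 mL.min-1.g-1 to 45 mL.min-1.g-1.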

Compound 4, intrinsic clearance in microsomes: 27 mL.min-1.g-1
The estimate for compound 4 lay 1.2-fold (0.09 log units) below the measured number, within the range that was stated.
By their numbers in this assay, from the lowest: compound 2; then compounds 1, 4 and 3 (each within the scatter of the next).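

In this assay, replacing 1-methyl-1H-pyrazol-4-yl with 1,3-dimethyl-1H-pyrazol-4-yl gives a 1.3-fold higher number from compound 1 to compound 4 (0.11 log units; within the scatter) and so leaves clearance within the scatter at this aromatic carbon next to the ring nitrogen. Among these compounds, this single pair is the first one-place comparison and says nothing about the same change on other cores. No measurement available here explains the size of this step. Still open, from the compounds shown here alone, is how clearance responds to a larger group at this carbon, such as ethyl, or to an amine or a carboxylic acid there.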